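The compounds below may be only part of what the source reports. "The series", "measured", "known", "first", "only" and "open" are said of these compounds alone.

Three compounds share one core and differ only in the group attached through a chain to one amine nitrogen. Compound 1 `c1ccc2c(c1)CN[C@@H](CN(CCCCNCC1CCNCC1)[C@H]1CCCc3cccnc31)C2` gives 36.5 nM in a functional assay on cells for antagonist activity at C-X-C chemokine receptor type 4 (Homo sapiens), read by fluorescence and calcium flux, with stated times of 25 min and 90 s; a lower number here means a stronger inhibitor, a higher number a weaker inhibitor. Compound 2 `NCc1ccccc1CN(C[C@H]1Cc2ccccc2CN1)[C@H]1CCCc2cccnc21` gives 50.8 nM in this assay, and compound 3 `CC(C)(CN)CCN(C[C@H]1Cc2ccccc2CN1)[C@H]1CCCc2cccnc21` gives 69 nM in this assay. Compound 3 thus shows the highest of the three numbers, yet every step among them lies within the scatter: a 1.4-fold higher number from compound 1 to compound 2 (0.14 log units; within the scatter), a 1.9-fold higher number from compound 1 to compound 3 (0.28 log units; within the scatter) and a 1.4-fold higher number from compound 2 to compound 3 (0.13 log units; within the scatter). Compound 4 `CC(C)(CCN(C[C@H]1Cc2ccccc2CN1)[C@H]1CCCc2cccnc21)CNC1CCC(F)(F)CC1` arises from compound 3 through (4,4-difluorocyclohexyl in place of hydrogen on an amine nitrogen). For the measured compounds named here, no measured step touches this amine nitrogen directly; the three steps show only that quite different groups in this outer region leave the number within the scatter. Compound 4 is therefore expected to change little, a 1.2-fold lower number from compound 3 to compound 4 (0.06 log units; within the scatter), with an estimate of 60 nM and a range from 20 nM to 180 nM.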

Compound 4, half-maximal inhibitory concentration: 168 nM
Compound 4: middle estimate off by 2.8-fold (0.45 log units), on the low side; the measured number falls inside the stated range.
By their numbers in this assay, from the lowest: compounds 1, 2 and 3 (each within the scatter of the next); then compound 4.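

Placing 4,4-difluorocyclohexyl in place of hydrogen on this amine nitrogen gives a 2.4-fold higher number from compound 3 to compound 4 (0.39 log units; beyond the scatter) in this assay, the first step in this series beyond the scatter. This position therefore responds to substitution, although the step is modest and the earlier changes, made elsewhere in the outer region, stayed within the scatter. No measurement shown explains the step. On these data alone, whether it follows from the ring itself or from its two fluorine atoms remains open, and a plain cyclohexyl or a methyl on this nitrogen would help to separate them.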